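Swapping the Sulfone for a Nitrile on the Shared Core

The source may hold more compounds than are shown below. What is called first, only, known or untested is meant among the compounds shown, and "the series" means these compounds.

Three compounds share one core. Compound 1 `CC(C)(C)OC(=O)N1CCC(O[C@H]2CC[C@H](Oc3ccc(S(C)(=O)=O)cn3)CC2)CC1` gives 47 nM in a functional assay on isolated protein for agonist activity at Glucose-dependent insulinotropic receptor (Homo sapiens), read by HTRF and cAMP accumulation; on this read-out higher numbers stand for an effect only at larger amounts of compound and lower numbers for an effect already at smaller amounts. Compound 2 `CC(C)(C)OC(=O)N1CCC(O[C@H]2CC[C@H](Oc3cnc(S(C)(=O)=O)cn3)CC2)CC1` gives 5.9 nM in this assay, and compound 3 `CC(C)S(=O)(=O)c1cnc(O[C@H]2CC[C@H](OC3CCN(C(=O)OC(C)(C)C)CC3)CC2)cn1` gives 18.5 nM in this assay. Compound 3 thus stands second highest of the three, with compound 1 above it and compound 2 below it. Two steps describe the set: an 8.0-fold lower number from compound 1 to compound 2 (0.90 log units; beyond the scatter) came with the ring exchange, and a 3.1-fold higher number from compound 2 to compound 3 (0.50 log units; beyond the scatter) came with isopropyl replacing methyl on the sulfonyl sulfur. Compound 4 `CC(C)(C)OC(=O)N1CCC(O[C@H]2CC[C@H](Oc3cnc(C#N)cn3)CC2)CC1` carries cyano in place of isopropylsulfonyl on an aromatic carbon. Among the measured compounds shown here, only the step from compound 2 to compound 3 touches this position, and it favoured the smaller group, since compound 2 gave 5.9 nM. In this assay the expected step is a 1.5-fold lower number from compound 3 to compound 4 (0.19 log units; within the scatter). Compound 4 is therefore estimated at 12 nM, with a range from 3 nM to 50 nM.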

Compound 4, half-maximal effective concentration: 8.3 nM
Compound 4: middle estimate off by 1.4-fold (0.16 log units), on the high side; measured number inside the range.
By their numbers in this assay, from the lowest: compounds 2 and 4 (each within the scatter of the next); then compound 3; then compound 1.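

In this assay, a sulfonyl group is not needed at this position: cyano gives a number level with methylsulfonyl (a 1.4-fold higher number from compound 2 to compound 4 (0.15 log units; within the scatter)). Cyano also gives a lower number than isopropylsulfonyl (a 2.2-fold lower number from compound 3 to compound 4 (0.35 log units; beyond the scatter)), and the exchange of the whole aromatic group on the oxygen, ring included, gives a lower number still (a 5.7-fold lower number from compound 1 to compound 4 (0.75 log units; beyond the scatter)). No measurement at hand explains why these groups behave alike or differ. Going by these compounds, whether an amine or a carboxylic acid at this position would keep the number this low remains open, as does how cyano would behave on the ring of compound 1.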